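Cyclopentenyl for Pyridyl on a Biaryl Amide Scaffold

The source may report more compounds than this note shows. Statements on the series, on what has been measured and on what is new or still open speak of the compounds shown alone.

Measured compounds:
Compound 1: `CC[C@H](C)[C@H](N)CN(C(=O)[C@@H]1C[C@H]1c1cccc(C)c1)c1ccc(-c2ccccc2)cc1` gives 1200 nM
Compound 2: `CC(C)C[C@H](N)CN(C(=O)[C@@H]1C[C@H]1c1ccccc1)c1ccc(-c2ccncc2)cc1` gives 13000 nM

In a functional assay for agonist activity at G protein-coupled receptor 88 (Homo sapiens), read by HTRF and cAMP accumulation (on this read-out higher numbers stand for an effect only at larger amounts of compound and lower numbers for an effect already at smaller amounts), compound 2 stands at the highest of the two numbers; the nearest value belongs to compound 1, whose number is lower, beyond the scatter. Compound 3, `CC(C)C[C@H](N)CN(C(=O)[C@@H]1C[C@H]1c1ccccc1)c1ccc(C2=CCCC2)cc1`, carries cyclopent-1-en-1-yl in place of pyridin-4-yl on an aromatic carbon. For the measured compounds named here, no measured pair shows this change. Going by the values given here, since compound 1, the only compound without a nitrogen in this outer ring, gives 1200 nM, a step toward a lower number is expected in this assay, of moderate size, a 3.7-fold lower number from compound 2 to compound 3 (0.57 log units; beyond the scatter). Compound 3 is therefore estimated at 3500 nM, within a range of 900 nM to 13000 nM.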

Compound 3, half-maximal effective concentration: 1200 nM
For compound 3 the middle estimate is 2.9-fold (0.46 log units) above the measured one, within the range that was stated.
By their numbers in this assay, from the lowest: compounds 1 and 3 (each within the scatter of the next); then compound 2.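

In this assay cyclopent-1-en-1-yl in place of pyridin-4-yl gives an 11-fold lower number from compound 2 to compound 3 (1.03 log units; beyond the scatter) on this aromatic carbon, para to a large group. For the compounds shown here, this is the first single-place change at this position, and it shows that neither an aromatic outer ring nor a ring nitrogen is required here for the lower number. No measured evidence bears on why the step occurs.

Going by these compounds, whether saturated cyclopentyl or pyridin-3-yl would give a similar number stays open. So does whether the same change carries over to the core of compound 1.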